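This account rests on a few compounds, and the source may have more. Where it says the series, first, only, none or still open, it means among the compounds named here.

Series notes, alpha-1D agonism. Compound 1 `Cn1nccc1-c1ccccc1NCC1=NCCN1` has only a limit in an in vitro functional assay on cells (Fibroblast) for agonist activity at Alpha-1D adrenergic receptor (Homo sapiens); a higher number here means that more compound is needed for the effect, a lower number that less compound is needed: the value of compound 1 is reported as < 100000 nM, a limit of the assay rather than a number. Compound 2 `c1ccc(-c2nc[nH]n2)c(NCC2=NCCN2)c1` carries 1H-1,2,4-triazol-3-yl in place of 1-methyl-1H-pyrazol-5-yl on an aromatic carbon; in this assay compound 2 gives 3.98 nM. The step that the limit leaves unreadable from compound 1 to compound 2 cannot be sized, because the limit of < 100000 nM in this assay, at which 1 of the 2 values shown sits, hides where compound 1 actually stands.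

Compound 3 `CCn1nccc1-c1ccccc1NCC1=NCCN1` differs from compound 1 by methyl in place of hydrogen on a saturated chain carbon bound to an aromatic nitrogen. Going by the values given here, no measured step touches this change; the only measured step concerns the heteroaryl swap and is itself unreadable. The expectation for this assay therefore rests on compound 1 alone, and its step that the limit leaves unreadable from compound 1 to compound 3 is estimated as small, with the wide uncertainty that the limit on compound 1 imposes. For compound 3 the estimate in this assay is 3000 nM, with a range of 30 nM to 100000 nM.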

Compound 3, half-maximal effective concentration: < 100000 nM
Compound 3 was reported as a limit; the forecaster's own chance of this, stated with the estimate: 40%; the middle value does not contradict the limit.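

Compound 1 and compound 3 both stand only as limits in this assay, so no step between them can be read: the limit of < 100000 nM in this assay, at which 2 of the 3 values shown sit.

The compounds shown leave open where compound 1 and compound 3 actually stand, and whether the change from methyl to ethyl alters the response at all.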